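The source may report more compounds than this note shows. Statements on the series, on what has been measured and on what is new or still open speak of the compounds shown alone.

Compound 3 `COc1cc(NC(C)CCCNC(=O)Nc2cccc(Cl)c2)c2ncccc2c1` sits second highest of the three numbers measured in a functional assay on CCRF-CEM cells (Homo sapiens) for inhibition, read by MTT assay, with a stated time of 72 h (on this read-out lower numbers stand for stronger inhibition and higher numbers for weaker inhibition), giving 22000 nM. Its nearest neighbour is compound 2 `COc1cc(NC(C)CCCNC(=O)Nc2cccc(F)c2)c2ncccc2c1`, which gives 21000 nM, a difference a 1.0-fold higher number from compound 2 to compound 3 (0.02 log units; within the scatter). Furthest away is compound 1 `COc1cc(NC(C)CCCNC(=O)NNC(=O)Nc2cccc(F)c2)c2ncccc2c1`, with 98000 nM, reached through the step of a 4.5-fold lower number from compound 1 to compound 3 (0.65 log units; beyond the scatter). Compound 4 `COc1cc(NC(C)CCCNC(=O)Nc2ccc(Cl)cc2)c2ncccc2c1` differs from compound 3 only in one place: 4-chlorophenyl in place of 3-chlorophenyl on an amide-type nitrogen. Among the compounds with values here, no measured step moves the chloro around the ring; the only step touching the halogen, a 1.0-fold higher number from compound 2 to compound 3 (0.02 log units; within the scatter), lay within the scatter, while the steps of a 4.7-fold lower number from compound 1 to compound 2 (0.67 log units; beyond the scatter) and a 4.5-fold lower number from compound 1 to compound 3 (0.65 log units; beyond the scatter) concern a different part of the molecule. Compound 4 is therefore expected to show a step of no change at the digits printed from compound 3 to compound 4 (within the scatter), with an estimate for compound 4 of 22000 nM, between 9000 nM and 55000 nM.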

Compound 4, half-maximal inhibitory concentration: 24000 nM
Estimate against measurement, compound 4: 1.1-fold (0.04 log units) below; the range from low to high includes it.
By their numbers in this assay, from the lowest: compounds 2, 3 and 4 (each within the scatter of the next); then compound 1.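

In this assay, the position of the chloro on the phenyl group carried by the amide-type nitrogen now has a reading: 4-chlorophenyl in place of 3-chlorophenyl gives a 1.1-fold higher number from compound 3 to compound 4 (0.04 log units; within the scatter), and 4-chlorophenyl in place of 3-fluorophenyl gives a 1.1-fold higher number from compound 2 to compound 4 (0.06 log units; within the scatter). Within the data shown here, the only new step beyond the scatter again involves loss of the ((3-fluorophenyl)carbamoyl)amino group, with a 4.1-fold lower number from compound 1 to compound 4 (0.61 log units; beyond the scatter). Going by these compounds, whether an amine or a carboxylic acid on that phenyl ring, or a longer chain, would shift the number stays open. Nothing available here bears on why the values fall as they do.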